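The compounds below may be only part of what the source reports. "The series", "measured", "known", "first", "only" and "open" are said of these compounds alone.

The measured compounds and their values in a functional assay (Oryctolagus cuniculus) for inhibition of platelet-activating factor receptor (Cavia porcellus); a lower number here means a stronger inhibitor, a higher number a weaker inhibitor:
compound 1, `CCCCCC(=O)OCC1CN(C(=O)c2cc(OC)c(OC)c(OC)c2)CCN1C(=O)c1cc(OC)c(OC)c(OC)c1`, gives 290 nM;
compound 2, `CCCCCCCCCC(=O)OCC1CN(C(=O)c2cc(OC)c(OC)c(OC)c2)CCN1C(=O)c1cc(OC)c(OC)c(OC)c1`, gives 2820 nM;
compound 3, `COc1cc(C(=O)N2CCN(C(=O)c3cc(OC)c(OC)c(OC)c3)C(COC(=O)C3CCCCC3)C2)cc(OC)c1OC`, gives 290 nM.

Compound 3 stands level with compound 1 at the digits shown, and the two together hold the lowest numbers of the three; the step of no change at the digits printed from compound 1 to compound 3 (within the scatter) lies within the scatter, whereas compound 2 sits apart, as a 9.7-fold lower number from compound 2 to compound 3 (0.99 log units; beyond the scatter) shows. Compound 4, `CCC(C)(C)NC(=O)OCC1CN(C(=O)c2cc(OC)c(OC)c(OC)c2)CCN1C(=O)c1cc(OC)c(OC)c(OC)c1`, differs from compound 3 in one place: (1,1-dimethylpropyl)amino in place of cyclohexyl on a carbonyl carbon. Of the measured steps, no change at the digits printed from compound 1 to compound 3 (within the scatter) bears most directly on this change: it exchanges one group for another of equal heavy-atom count on this carbonyl carbon and leaves the number unchanged. The step of a 9.7-fold higher number from compound 1 to compound 2 (0.99 log units; beyond the scatter) shows that a longer chain on that carbon raised the number by a modest amount. For the measured compounds named here, the group entering in compound 4 matches the cyclohexyl it replaces in heavy-atom count, but brings a hydrogen-bond donor that none of the measured groups on that carbonyl carbon carries; no measured step speaks to that feature. The expectation is therefore a small step at most in this assay, a 1.4-fold higher number from compound 3 to compound 4 (0.14 log units; within the scatter), in no firm direction. The estimate for compound 4 in this assay is 400 nM, with a range from 150 nM to 1200 nM.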

Compound 4, half-maximal inhibitory concentration: 320 nM
For compound 4 the middle estimate is 1.3-fold (0.10 log units) above the measured one, and the stated range covers the measured number.
By their numbers in this assay, from the lowest: compounds 1, 3 and 4 (each within the scatter of the next); then compound 2.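

In this assay, a hydrogen-bond donor and an open branched group can take the place of the ring on this carbonyl carbon without a step beyond the scatter: the exchange gives a 1.1-fold higher number from compound 3 to compound 4 (0.04 log units; within the scatter), and the comparison with the straight pentyl group gives a 1.1-fold higher number from compound 1 to compound 4 (0.04 log units; within the scatter). Compound 4 also stands well apart from the nonyl ester, with an 8.8-fold lower number from compound 2 to compound 4 (0.95 log units; beyond the scatter), so the position tolerates quite different groups among those shown, while nonyl, in compound 2, is the one that goes against this tolerance. No independent measurement bears on this result.

The compounds shown leave open whether the hydrogen-bond donor would behave in the same way with other groups on this carbon, such as cyclohexylamino, which would separate the donor from the loss of the ring, or nonylamino, which would show whether the nitrogen alters what the long chain does. They also leave open how an aromatic ring such as phenyl would fare on this carbonyl carbon, and whether a chain between pentyl and nonyl, such as heptyl, already sits apart.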